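Swapping an ethylphenyl for a naphthyl on a shared core

The source may report more compounds than this note shows. Statements on the series, on what has been measured and on what is new or still open speak of the compounds shown alone.

In a functional assay on ACHN cells (Homo sapiens) for inhibition, read by sulforhodamine B assay, with a stated time of 48 h, tested at 10 uM (a higher number here means more inhibition at the concentration tested (going by the name of the read-out), a lower number less inhibition), compound 3 `CCc1ccc(-c2cn3ccnc3c(-c3ccc4ncn(Cc5ccccc5)c4c3)n2)cc1` gives 44.7%, the highest of the three measured compounds. Among the measured compounds shown here, compound 1 `Brc1cn2ccnc2c(-c2ccc3ncn(C4CCCCC4)c3c2)n1` gives 11.5% and compound 2 `Fc1ccc(-c2cn3ccnc3c(-c3ccc4ncn(C5CCCCC5)c4c3)n2)cc1` gives 9.02%; the only measured step, a number 2.5 percentage points lower from compound 1 to compound 2 (within the scatter), lies within the scatter. Compound 4 `c1ccc(Cn2cnc3ccc(-c4nc(-c5cccc6ccccc56)cn5ccnc45)cc32)cc1` differs from compound 3 in one place: naphthalen-1-yl in place of 4-ethylphenyl on an aromatic carbon. For the measured compounds named here, none of the measured steps swaps one ring group for another of this kind, and compounds 1 and 2 also differ from compound 3 elsewhere, so the measured step gives no guide to the direction of this change. The expected step is therefore none beyond the scatter, a number 4.7 percentage points lower from compound 3 to compound 4 (within the scatter). Compound 4 is estimated at 40%, with a range from 15% to 65%.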

Compound 4, a percentage reported as inhibition, at one concentration (the size of the read-out at that concentration, not a potency): 12.4%
The estimate for compound 4 lay 27.6 percentage points above the measured number; measured number outside the range, below it.
By their numbers in this assay, from the lowest: compounds 2, 1 and 4 (each within the scatter of the next); then compound 3.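

This position on the shared core is sensitive to which aromatic group it carries: in this assay, naphthalen-1-yl in place of 4-ethylphenyl gives a number 32.3 percentage points lower from compound 3 to compound 4 (beyond the scatter). Neither group has hydrogen-bond donors, hydrogen-bond acceptors or a net charge, so those counts do not separate them, although the second aromatic ring of naphthalen-1-yl does. No measurement at hand explains this difference.

The compounds shown leave open whether the ethyl group or the single ring matters more. They also do not show how an unsubstituted phenyl, a 4-propylphenyl or a 4-aminophenyl would behave here.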